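Furan in place of pyridine on the benzylic arm

The source may report more compounds than this note shows. Statements on the series, on what has been measured and on what is new or still open speak of the compounds shown alone.

For the measured compounds named here, compound 3 `O=c1c(-c2cccc([N+](=O)[O-])c2)nc2ccccc2n1Cc1ccccn1` stands second highest of the three numbers known here in an assay on cells for activation of Cystic fibrosis transmembrane conductance regulator (Homo sapiens), read by fluorescence, with a stated time of 10 min (on this read-out lower numbers stand for an effect already at smaller amounts and higher numbers for an effect only at larger amounts of compound), where compound 3 gives 52 nM. Compound 1 `O=c1c(-c2cccc([N+](=O)[O-])c2)nc2ccccc2n1Cc1ccccc1` gives 9 nM, and the step of a 5.8-fold higher number from compound 1 to compound 3 (0.76 log units; beyond the scatter) was the modest one that set compound 3 apart. Compound 2 `O=c1c(-c2cccc([N+](=O)[O-])c2)nc2ccccc2n1Cc1ccc2ccccc2c1` gives 4300 nM, the step of a 480-fold higher number from compound 1 to compound 2 (2.68 log units; beyond the scatter) being the large one of the set, while an 83-fold lower number from compound 2 to compound 3 (1.92 log units; beyond the scatter) runs back the other way. Compound 4 `O=c1c(-c2cccc([N+](=O)[O-])c2)nc2ccccc2n1Cc1ccco1` differs from compound 3 in one place: furan-2-yl in place of pyridin-2-yl on a saturated chain carbon bound to an aromatic nitrogen. Of the measured steps, only the exchange of one small ring for another in this position bears on it, and that step from compound 1 to compound 3 was modest; the large step came only with the two-ring group of compound 2, which compound 4 does not carry. A modest step, in either direction but not beyond the modest range, is therefore expected in this assay for compound 4, a 1.3-fold lower number from compound 3 to compound 4 (0.11 log units; within the scatter). Compound 4 is estimated at 40 nM, with a range from 10 nM to 160 nM.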

Compound 4, half-maximal effective concentration: 20 nM
The estimate for compound 4 lay 2.0-fold (0.30 log units) above the measured number, and the stated range covers the measured number.
By their numbers in this assay, from the lowest: compound 1; then compound 4; then compound 3; then compound 2.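

In this assay, a five-membered aromatic ring is accepted on the saturated chain carbon bound to an aromatic nitrogen: the exchange of pyridin-2-yl for furan-2-yl gives a 2.6-fold lower number from compound 3 to compound 4 (0.41 log units; beyond the scatter), while phenyl keeps the edge, with a 2.2-fold higher number from compound 1 to compound 4 (0.35 log units; beyond the scatter). The new compound also shows that the sharp loss stays with the naphthalen-2-yl group rather than with changes among the single rings, as the exchange for furan-2-yl gives a 220-fold lower number from compound 2 to compound 4 (2.33 log units; beyond the scatter). No measurement here explains why furan-2-yl gives a lower number than pyridin-2-yl.

Ring size and the hetero atom change together in this step, so their separate contributions cannot be read. From the compounds shown here alone, whether a longer chain carrying the furan-2-yl ring, or an amine in place of that ring, would keep the number low remains open.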